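Chloro for fluoro on the cinnamoyl-type series

This account rests on a few compounds, and the source may have more. Where it says the series, first, only, none or still open, it means among the compounds named here.

Measured in a functional assay, read by spectrophotometry, tested at 100 uM; on this read-out higher numbers stand for weaker inhibition and lower numbers for stronger inhibition
compound 1 `O=C(/C=C/c1ccccc1)c1cccc(NC(=O)c2cc(-c3ccncc3)n[nH]2)c1` gives 67100 nM
compound 2 `O=C(/C=C/c1ccc(F)cc1)c1cccc(NC(=O)c2cc(-c3ccncc3)n[nH]2)c1` gives 56000 nM

In this assay compound 2 stands within the scatter of compound 1 and the two do not separate. Compound 3 `O=C(/C=C/c1ccc(Cl)cc1)c1cccc(NC(=O)c2cc(-c3ccncc3)n[nH]2)c1` follows from compound 2 through chloro in place of fluoro on an aromatic carbon with chloro in place of fluoro on an aromatic carbon, para to a large group. Among the measured compounds shown here, the only measured step on this carbon is a 1.2-fold lower number from compound 1 to compound 2 (0.08 log units; within the scatter) and it stays within the scatter. No change beyond the scatter is therefore expected, and a 1.1-fold lower number from compound 2 to compound 3 (0.05 log units; within the scatter) is the step estimated here. The estimate for compound 3 is 50000 nM with an expected range from 26000 nM to 98000 nM for a single measurement.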

Compound 3, half-maximal inhibitory concentration: 63900 nM
The estimate for compound 3 lay 1.3-fold (0.11 log units) below the measured number; low and high end bracket the measured number.
By their numbers in this assay, from the lowest: compounds 2, 3 and 1 (each within the scatter of the next).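

In this assay the step of a 1.1-fold higher number from compound 2 to compound 3 (0.06 log units; within the scatter) and the step of a 1.1-fold lower number from compound 1 to compound 3 (0.02 log units; within the scatter) both stay within the scatter. Hydrogen, fluoro and chloro on this aromatic carbon, para to a large group, therefore do not separate, and the chloro adds no measurable difference to what fluoro already showed. Nothing available accounts for this flat reading.

On these data alone, whether an amine, a carboxylic acid or a methoxy group on this carbon would move the number beyond the scatter remains open. Also open, as far as these compounds go, is whether replacing the amide hydrogen in the shared core would do so.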